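Replacing isobutyl with hydrogen on the aromatic nitrogen

This account rests on a few compounds, and the source may have more. Where it says the series, first, only, none or still open, it means among the compounds named here.

Three measured compounds share one core. In a functional assay on L929 cells (Mus musculus) for inhibition, read by MTT assay, with a stated time of 5 days (on this read-out lower numbers stand for stronger inhibition and higher numbers for weaker inhibition), compound 1 `COc1ccc(N(Cc2ccccc2)CC(C)C)cc1` gives 10 ug/mL. Compound 2 `COc1ccc(N(Cc2ccccc2OC)CC(C)C)cc1` gives 15 ug/mL, and compound 3 `COc1ccc(N(Cc2ccccc2)Cc2ccccc2)cc1` gives 12 ug/mL. Compound 2 carries the highest of the three numbers only nominally, since its gaps to compound 3 and compound 1 both lie within the scatter, as a 1.5-fold higher number from compound 1 to compound 2 (0.18 log units; within the scatter) shows.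

Compound 4 `COc1ccc(NCc2ccccc2OC)cc1` differs from compound 2 by hydrogen in place of isobutyl on a nitrogen on an aromatic ring. Within the data shown here, no measured step touches this nitrogen's substituent: a 1.5-fold higher number from compound 1 to compound 2 (0.18 log units; within the scatter) and a 1.2-fold higher number from compound 1 to compound 3 (0.08 log units; within the scatter) alter other places and each stayed within the scatter. With no direct guide, the expected step for compound 4 is no change at the digits printed from compound 2 to compound 4 (within the scatter) in this assay, that is, nothing beyond the scatter. Compound 4 is therefore estimated at 15 ug/mL, within a range from 6 ug/mL to 40 ug/mL.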

Compound 4, half-maximal inhibitory concentration: 25 ug/mL
Beside the measured number, compound 4's estimate is 1.7-fold (0.22 log units) below it; low and high end bracket the measured number.
By their numbers in this assay, from the lowest: compounds 1, 3, 2 and 4 (each within the scatter of the next, the first and the last beyond it).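

Among these compounds, this is the first step that touches the nitrogen on an aromatic ring itself. In this assay the step is a 1.7-fold higher number from compound 2 to compound 4 (0.22 log units; within the scatter) when hydrogen takes the place of isobutyl. On compound 2, then, this nitrogen can lose the whole isobutyl group and keep a hydrogen without a shift beyond the scatter, although this single pair cannot show whether the same holds on compound 1 or compound 3.

Going by these compounds, how a longer chain or a carboxylic acid on this nitrogen would read remains open. Nothing available explains why this swap leaves the number within the scatter.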